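A Side-Chain Swap at the Limit of the Assay

The source may hold more compounds than are shown below. What is called first, only, known or untested is meant among the compounds shown, and "the series" means these compounds.

In a toxicity assay on HeLa cells (Homo sapiens) for cytotoxicity, read by colorimetric assay, with a stated time of 72 h (a lower number here means that less compound is tolerated, a higher number that more compound is tolerated), compound 1 `N#Cc1ccccc1N1CCN(c2nc(=O)c3cc(C(F)(F)F)cc([N+](=O)[O-])c3s2)CC1` gives only a limit (> 108000 nM). Compound 2 `COc1cc(OC)cc(N2CCN(c3nc(=O)c4cc(C(F)(F)F)cc([N+](=O)[O-])c4s3)CC2)c1` also gives only a limit (> 101000 nM), so its standing is known only as that limit. For the measured compounds named here, the one measured step that the two limits leave unreadable from compound 1 to compound 2 therefore has no readable size. Compound 3 `CN(C(=O)CN1CCN(c2nc(=O)c3cc(C(F)(F)F)cc([N+](=O)[O-])c3s2)CC1)c1ccccc1` carries (methyl(phenyl)carbamoyl)methyl in place of 3,5-dimethoxyphenyl on an amine nitrogen in a ring. With no readable size to carry over, no change beyond the scatter is expected in this assay, and the estimated step is a number no higher from compound 2 to compound 3 (the limit leaves the size open). For compound 3 the estimated half-maximal cytotoxic concentration is 100000 nM, with an expected range of 40000 nM to 200000 nM.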

Compound 3, half-maximal cytotoxic concentration: 70300 nM
Estimate against measurement, compound 3: 1.4-fold (0.15 log units) above; measured number inside the range.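

In this assay, for the compounds shown here, compound 3 gives 70300 nM, the only one of the three values at this position that is a number and not a limit of the assay. Placing (methyl(phenyl)carbamoyl)methyl on this amine nitrogen in a ring gives an at least 1.4-fold lower number from compound 2 to compound 3 (0.15 log units; that floor lies within the scatter) and an at least 1.5-fold lower number from compound 1 to compound 3 (0.18 log units; that floor lies within the scatter), so no change beyond the scatter is established. The step from compound 2 remains only a floor because its starting value is a limit: the limit of > 101000 nM in this assay, at which 1 of the 3 values shown sits.

Still open, on these data alone, is whether a carboxylic acid or an amine at the end of a longer chain on this nitrogen would give a number clearly lower in this assay.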